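The compounds below may be only part of what the source reports. "The series", "measured", "known", "first", "only" and "open" are said of these compounds alone.

Compound 1: `CCC1(C)CC(=O)N(CC(=O)N2CCN(c3ccc(Cl)cc3)CC2)C1=O` gives 100 mg/kg.
Compound 2: `CCC1(C)CC(=O)N(CC(=O)N2CCN(c3ccccc3C)CC2)C1=O` gives 100 mg/kg.

Compound 1 and compound 2 were tested in a functional assay on the whole organism (strain CD1) with Mus musculus as the target, with a stated time of 0.5 h; on this read-out lower numbers stand for an effect already at smaller amounts and higher numbers for an effect only at larger amounts of compound. Compound 2 stands level with compound 1 at the digits shown, and the step of no change at the digits printed from compound 1 to compound 2 (within the scatter) lies within the usual scatter. Compound 3, `CCC1(C)CC(=O)N(CC(=O)N2CCN(c3ccc(F)cc3)CC2)C1=O`, has not yet been measured. It differs from compound 2 in one place: 4-fluorophenyl in place of 2-methylphenyl on an amine nitrogen in a ring. Among the measured compounds shown here, the only measured step that bears on this change is the one from compound 1 to compound 2, in which a 4-chlorophenyl gave way to a 2-methylphenyl on the same ring nitrogen with no change beyond the scatter. A 4-fluorophenyl is, like the 4-chlorophenyl of compound 1, a halogen-bearing phenyl, so no step beyond the scatter is expected in this assay. For compound 3 the estimated step of no change at the digits printed from compound 2 to compound 3 (within the scatter) is close to none. Compound 3 is therefore expected to give about 100 mg/kg, in the range 50 mg/kg to 300 mg/kg.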

Compound 3, minimum effective dose: 100 mg/kg
Compound 3: middle estimate and measured number agree at the digits printed; the measured number falls inside the stated range.
By their numbers in this assay, from the lowest: compounds 1, 2 and 3 (each within the scatter of the next).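

In this assay, 4-fluorophenyl in place of 2-methylphenyl on the amine nitrogen in the ring gives no change at the digits printed from compound 2 to compound 3 (within the scatter), and fluoro in place of chloro on an aromatic carbon gives no change at the digits printed from compound 1 to compound 3 (within the scatter). Three different substituted phenyl groups on this nitrogen now read alike, and the exchange of one halogen for another, with the rest of the molecule kept the same, adds a cleaner comparison than the earlier step, which replaced one substituted phenyl with a differently substituted one. No measurement shown offers a reason for this sameness.

On these data alone, all three compounds carry a phenyl ring with a single small group on this nitrogen, so it stays open whether a phenyl bearing a carboxylic acid or an amine would read the same. As far as these compounds go, a longer alkyl chain in place of the phenyl, and any change to the shared core, also remain untested by these compounds.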